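This account rests on a few compounds, and the source may have more. Where it says the series, first, only, none or still open, it means among the compounds named here.

Compound 1 `OC[C@H](NC[C@H]1NC[C@H](O)[C@@H]1O)c1ccc(-c2ccccc2)cc1` sits only at a limit of a functional assay on MCF7 cells (Homo sapiens) for cytotoxicity, read by colorimetric assay, with a stated time of 72 h (a lower number here means a stronger inhibitor, a higher number a weaker inhibitor), where compound 1 gives > 200000 nM and no number. Compound 2 `OC[C@H](NC[C@H]1NC[C@H](O)[C@@H]1O)c1ccc(-c2ccc(C(F)(F)F)cc2)cc1` gives 77000 nM in this assay. Among the compounds with values here, the one measured step, an at least 2.5-fold lower number from compound 1 to compound 2 (0.41 log units; beyond the scatter), concerns a different change from the one now at hand, so it offers no direct guide. Compound 3 `OC[C@H](NC[C@H]1NC[C@H](O)[C@@H]1O)c1ccc(-c2ccsc2)cc1` differs from compound 1 by thiophen-3-yl in place of phenyl on an aromatic carbon. With nothing comparable measured, compound 3 is expected to show no step beyond the scatter, an at least 1.3-fold lower number from compound 1 to compound 3 (0.12 log units; that floor lies within the scatter), so the estimate for compound 3 is 150000 nM, between 40000 nM and 300000 nM.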

Compound 3, half-maximal inhibitory concentration: "not active" (no number reported)
No number was reported for compound 3, so the estimate cannot be set against anything.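

Within the data shown here, compound 3 is reported only as "not active" and compound 1 stands only at a limit, so no step between them can be read. The compounds shown leave open how thiophen-3-yl in place of phenyl moves the number in this assay.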